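Series notes: extending the alkoxy group from compound 3 to compound 4

The compounds below may be only part of what the source reports. "The series", "measured", "known", "first", "only" and "open" are said of these compounds alone.

Compound 3 `CCOc1ccc(N2CCc3c(-n4ccc(N5CCNC5=O)n4)cc(C)nc32)c(C)c1` gives 316 nM in an assay on CHO cells for displacement of a labelled ligand from corticotropin-releasing factor receptor 1 (Homo sapiens) (a higher number here means a weaker inhibitor, a lower number a stronger inhibitor), the second highest of the three numbers measured. Compound 1 `COc1ccc(N2CCc3c(-n4ccc(N5CCNS5(=O)=O)n4)cc(C)nc32)c(C)c1` gives 309 nM in this assay, a number within the scatter of compound 3; compound 2 `COc1ccc(N2CCc3c(-n4ccc(N5CCOC5=O)n4)cc(C)nc32)c(C)c1` gives 1950 nM, the highest of the three and beyond the scatter from compound 3. For the measured compounds named here, the one single-point step measured, a 6.3-fold higher number from compound 1 to compound 2 (0.80 log units; beyond the scatter), concerns the five-membered non-aromatic ring on the aromatic carbon and not the aryl ether.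

Compound 4 `Cc1cc(-n2ccc(N3CCNC3=O)n2)c2c(n1)N(c1ccc(OC(C)C)cc1C)CC2` differs from compound 3 by methyl in place of hydrogen on a saturated chain carbon bound to an oxygen on an aromatic ring and a saturated chain carbon; cut one bond further out this reads ethoxy to isopropoxy. Going by the values given here, no measured step touches this position: compound 1 and compound 3 differ at the alkoxy group and at the five-membered ring together, so their values, which lie within the scatter of each other, do not isolate the alkoxy change. Nothing measured argues for a shift beyond the scatter in this assay in either direction. The expected step is a 1.0-fold higher number from compound 3 to compound 4 (0.01 log units; within the scatter). Compound 4 is therefore estimated at 320 nM, with a range from 120 nM to 850 nM.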

Compound 4, half-maximal inhibitory concentration: 1230 nM
Beside the measured number, compound 4's estimate is 3.8-fold (0.58 log units) below it; measured number outside the range, above it.
By their numbers in this assay, from the lowest: compounds 1 and 3 (each within the scatter of the next); then compounds 4 and 2 (each within the scatter of the next).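

The alkoxy group is not a silent position in this assay: ethoxy to isopropoxy gives a 3.9-fold higher number from compound 3 to compound 4 (0.59 log units; beyond the scatter) and so moves the number beyond the scatter. For the compounds shown here, the earlier compounds could not show this, as their only measured step concerned the five-membered ring and not the aryl ether. No measurement at hand bears on the reason for this step.

Going by these compounds, whether the step follows the branch at this saturated chain carbon or the added methyl as such stays open, and a straight propoxy chain on the core of compound 3 would separate the two. Also open, on these data alone, is whether isopropoxy in place of methoxy would give a step of similar size with the rings of compound 1 and compound 2.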